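A few compounds are considered here, and "the series" means these few. Any claim that something is new, unique, unknown or untested is made for them only; others in the source may bear on it.

Compound 1 `CC[C@H](C)C(N)c1cc(C(F)(F)F)ccc1N1CCN(C(=O)CCc2ccc(Cl)cc2Cl)CC1`: 75 nM
Compound 2 `CCC(C)[C@H](N)c1cc(C(F)(F)F)ccc1N1CCN(C(=O)CCc2ccc(OC)cc2Cl)CC1`: 57 nM

Of the compounds shown here, two have been measured in an assay on HEK293 cells for displacement of a labelled ligand from Melanocortin receptor 4 (Homo sapiens); a lower number here means a stronger inhibitor, a higher number a weaker inhibitor. Compound 1 gives 75 nM, which is the higher of the two numbers; the nearest value, that of compound 2, is lower by an amount that stays within the scatter, so the two cannot be ordered.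

The step considered here leads from compound 1 to compound 3 `CCC(C)[C@H](NC[C@@H]1CCCN1)c1cc(C(F)(F)F)ccc1N1CCN(C(=O)CCc2ccc(Cl)cc2Cl)CC1`, not yet measured in this assay. The change is 2-methyl-1-(((pyrrolidin-2-yl)methyl)amino)butyl in place of 1-amino-2-methylbutyl on an aromatic carbon. Within the data shown here, no measured pair shows this change, so the direction must be estimated from compound 1 alone. Nothing in the two measured values speaks for a large shift, and compound 3 is expected to land close to compound 1, the step of a 1.4-fold lower number from compound 1 to compound 3 (0.13 log units; within the scatter) being small and uncertain in direction. In this assay compound 3 is estimated at 55 nM, within a range from 12 nM to 250 nM.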

Compound 3, inhibition constant: 64 nM
For compound 3 the middle estimate is 1.2-fold (0.07 log units) below the measured one; measured number inside the range.
By their numbers in this assay, from the lowest: compounds 2, 3 and 1 (each within the scatter of the next).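

In this assay the step of a 1.2-fold lower number from compound 1 to compound 3 (0.07 log units; within the scatter) lies within the scatter, so 2-methyl-1-(((pyrrolidin-2-yl)methyl)amino)butyl in place of 1-amino-2-methylbutyl cannot be told apart from no change at this aromatic carbon. This position therefore takes a group with more heavy atoms, including a five-membered non-aromatic ring and a second nitrogen, with no shift that the numbers can resolve. No available measurement bears on why this is so.

The compounds shown leave open whether the ring itself matters, which a open-chain 2-(dimethylamino)ethyl group or a six-membered piperidine ring on the same nitrogen could test. They also leave open how a carboxylic acid on this side chain would read in this assay and whether larger groups here would still give no resolvable shift.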